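Aryl replacement on the carbonyl of compound 1

This account rests on a few compounds, and the source may have more. Where it says the series, first, only, none or still open, it means among the compounds named here.

Measured compounds:
compound 1 `COc1cc(-c2cc(/C=C/C(=O)c3ccc(Cl)c(Cl)c3)[nH]n2)cc(OC)c1OC` — 48%
compound 2 `COc1ccc(-c2cc(/C=C/C(=O)c3ccc(N)cc3)[nH]n2)cc1` — -94%

In a functional assay on U-251 cells (Homo sapiens) for cytotoxicity, read by sulforhodamine B assay, with a stated time of 48 h, tested at 10 uM (on this read-out higher numbers stand for a weaker effect at the one concentration tested and lower numbers for a stronger effect), compound 1 gives 48%, the highest of the two numbers in hand, so the weaker effect of the pair. In this assay, within the data shown here, compound 2 gives -94%, a number far lower than that of compound 1 and well beyond the scatter; the two differ in more than one place, so no single step is read from them.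

Compound 3 `COc1ccc(C(=O)/C=C/c2cc(-c3cc(OC)c(OC)c(OC)c3)n[nH]2)cc1OC` has not been measured. It differs from compound 1 as follows: 3,4-dimethoxyphenyl in place of 3,4-dichlorophenyl on a carbonyl carbon. The change is confined to the group on the carbonyl carbon, with the rest of the shared core left as in compound 1.

Among the measured compounds shown here, no measured pair isolates this change, so its size in this assay is not known from the data. The expectation is a modest move downward, that is toward a stronger effect, though a result within the scatter of compound 1 would not be surprising; this is what the expected step of a number 13 percentage points lower from compound 1 to compound 3 (beyond the scatter) means. For compound 3 the estimate is 35%, between -50% and 85%.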

Compound 3, a percentage reported as activity, at one concentration (the size of the read-out at that concentration, not a potency): -100%
Beside the measured number, compound 3's estimate is 135 percentage points above it; measured number below the stated range.
By their numbers in this assay, from the lowest: compounds 3 and 2 (each within the scatter of the next); then compound 1.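

In this assay, the group on the carbonyl carbon proves to be a strong determinant of the read-out: 3,4-dimethoxyphenyl in place of 3,4-dichlorophenyl, with the rest of the shared core left as it was, gives a number 148 percentage points lower from compound 1 to compound 3 (beyond the scatter). Among these compounds, this is the first step that can be assigned to one place, since the earlier gap came from two compounds differing in more than one place. The data in hand give no explanation for the size of this step.

Going by these compounds, it remains open whether the step follows the arrival of the two methoxy groups or the departure of the two chlorine atoms, and a single methoxy group, a 3,4-difluorophenyl group or a pyridyl ring on the carbonyl carbon of the same shared core would help to separate these two readings. Also open, on these data alone, is whether the step keeps its size when the rest of the core changes, and what a carboxylic acid or a morpholine on the aryl ring at this place would do to the read-out.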